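Cinnamide in place of tetrahydronaphthyl amide: compound 4

The compounds below may be only part of what the source reports. "The series", "measured", "known", "first", "only" and "open" are said of these compounds alone.

Measured so far:
compound 1 `CN1[C@@H]2c3[nH]c4ccccc4c3C[C@H]1[C@H](C#N)N1[C@@H](CN3C(=O)c4ccccc4C3=O)c3[nH]c4ccccc4c3C[C@@H]21` gives 40 nM
compound 2 `CN1[C@@H]2c3[nH]c4ccccc4c3C[C@H]1[C@H](C#N)N1[C@@H](CNC(=O)c3cccc4c3CCCC4)c3[nH]c4ccccc4c3C[C@@H]21` gives 4210 nM
compound 3 `CN1[C@@H]2c3[nH]c4ccccc4c3C[C@H]1[C@H](C#N)N1[C@@H](CNC(=O)c3ccc4ccccc4c3)c3[nH]c4ccccc4c3C[C@@H]21` gives 420 nM

In a functional assay on HCT-116 cells (Homo sapiens) for cytotoxicity, read by MTT assay, with a stated time of 72 h (a lower number here means a stronger inhibitor, a higher number a weaker inhibitor), compound 2 gives the highest of the three numbers; its nearest neighbour is compound 3, and compound 1 lies furthest from it. Within the data shown here, the one measured step that changes the same place is a 10-fold lower number from compound 2 to compound 3 (1.00 log units; beyond the scatter), in which a flat aromatic amide substituent replaces the partly saturated one.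

Compound 4 `CN1[C@@H]2c3[nH]c4ccccc4c3C[C@H]1[C@H](C#N)N1[C@@H](CNC(=O)/C=C/c3cccc(C(F)(F)F)c3)c3[nH]c4ccccc4c3C[C@@H]21` differs from compound 2 in the same place: 2-(3-(trifluoromethyl)phenyl)ethenyl in place of 1,2,3,4-tetrahydronaphthalen-5-yl on a carbonyl carbon. The entering group again carries an aromatic ring, now held away from the carbonyl through a double bond and bearing a trifluoromethyl group. Among the measured compounds shown here, only the step from compound 2 to compound 3 bears on this change; no measured compound carries a substituent of this kind, so the expectation is loosely held.

Given the step of a 10-fold lower number from compound 2 to compound 3 (1.00 log units; beyond the scatter), a lower number for compound 4 than for compound 2 is expected, and the estimated step of a 4.7-fold lower number from compound 2 to compound 4 (0.67 log units; beyond the scatter) is judged smaller than that one. In this assay compound 4 is expected to give 900 nM, with a range from 150 nM to 5000 nM.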

Compound 4, half-maximal inhibitory concentration: 610 nM
Beside the measured number, compound 4's estimate is 1.5-fold (0.17 log units) above it; the range from low to high includes it.
By their numbers in this assay, from the lowest: compound 1; then compounds 3 and 4 (each within the scatter of the next); then compound 2.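

In this assay, the lower number seen with the naphthalen-2-yl group of compound 3 is not unique to that group: a 6.9-fold lower number from compound 2 to compound 4 (0.84 log units; beyond the scatter) shows that 2-(3-(trifluoromethyl)phenyl)ethenyl on the same carbonyl carbon also lowers the number. The a 1.5-fold higher number from compound 3 to compound 4 (0.16 log units; within the scatter) shows that these two different entering groups cannot be told apart here, even though one carries a double bond outside the aromatic ring and trifluoromethyl, while the other has neither. No measurement is available that explains this result.

The compounds shown do not separate the contribution of the double bond from that of the trifluoromethyl group. On these data alone, it also remains open whether an amide carrying an amine or a carboxylic acid on that phenyl ring would come closer to compound 1, at 40 nM.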